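Quinoxaline dioxide nitriles: cytotoxicity in Vero cells

A few compounds are considered here, and "the series" means these few. Any claim that something is new, unique, unknown or untested is made for them only; others in the source may bear on it.

Measured so far:
- compound 1, `COc1ccc2c(c1)[n+]([O-])c(C#N)c(-c1ccc(Cl)cc1)[n+]2[O-]`: 1 ug/mL
- compound 2, `Cc1ccc(-c2c(C#N)[n+]([O-])c3cc(C)ccc3[n+]2[O-])cc1`: "nd(insoluble)" (no result reported)
- compound 3, `COc1ccc(-c2c(C#N)[n+]([O-])c3cc(F)ccc3[n+]2[O-])cc1`: 13 ug/mL

In an ADME assay on Vero cells (Chlorocebus sabaeus) for cytotoxicity, read by MTT assay, with a stated time of 72 h (on this read-out lower numbers stand for stronger inhibition and higher numbers for weaker inhibition), compound 1 gives 1 ug/mL, the lowest of the two numbers obtained. Compound 3 gives 13 ug/mL in this assay, a higher number than compound 1 by a margin beyond the usual scatter; compound 2 returned no number in this assay, being insoluble under the conditions. Among the compounds with values here, no pair of the measured compounds differs in a single place, so no single-change step is available to lean on.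

Compound 4, `COC(=O)c1ccc(-c2c(C#N)[n+]([O-])c3cc(OC)ccc3[n+]2[O-])cc1`, is the next entry for this assay. It differs from compound 1 as follows: methoxycarbonyl in place of chloro on an aromatic carbon. The change is on the pendant aryl ring, not on the shared core; compound 3 also carries a substituent on that ring and on the core and gives the higher number, but that comparison mixes two changes and cannot be read as a step.

Within the data shown here, with no clean precedent, a modest move to a higher number is expected for compound 4, with the step from compound 1 estimated as a 4.0-fold higher number from compound 1 to compound 4 (0.60 log units; beyond the scatter). Compound 4 is expected to give about 4 ug/mL in this assay, within 1 ug/mL to 15 ug/mL.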

Compound 4, half-maximal inhibitory concentration: 3.9 ug/mL
Compound 4: middle estimate off by 1.0-fold (0.01 log units), on the high side; low and high end bracket the measured number.
By their numbers in this assay, from the lowest: compound 1; then compound 4; then compound 3.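

In this assay, within the data shown here, the replacement of chloro by methoxycarbonyl on an aromatic carbon, para to a large group, gives the first single-change step: a 3.9-fold higher number from compound 1 to compound 4 (0.59 log units; beyond the scatter), a modest step but one beyond the scatter. The number at this position therefore responds to the group placed there, and a substituent with 4 heavy atoms and 2 hydrogen-bond acceptors, in place of 1 heavy atom and 0 hydrogen-bond acceptors, still leaves compound 4 at 3.9 ug/mL, a low single-digit number on this read-out. No measurement shown bears on the cause of this step.

Going by these compounds, because this rests on one pair, it gives a single step at this position and no trend, so it remains open whether an amine, a carboxylic acid or a longer chain on the same aromatic carbon would move the number further or bring it back towards that of compound 1. On these data alone, it also remains open whether the step from chloro to methoxycarbonyl would keep its size if the methoxy group on the shared core were replaced by a fluoro or methyl group.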